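Arylpiperazine spirooxindoles: predicting a 3,4-dichlorophenyl analogue

A few compounds are considered here, and "the series" means these few. Any claim that something is new, unique, unknown or untested is made for them only; others in the source may bear on it.

Measured in an assay on CHO cells for displacement of a labelled ligand from 5-hydroxytryptamine receptor 7 (Homo sapiens); a higher number here means a weaker inhibitor, a lower number a stronger inhibitor:
- compound 1 `CCC1(CCCCCN2CCN(c3cccc(Cl)c3)CC2)C(=O)Nc2ccccc21`: 1.45 nM
- compound 2 `CCC1(CCCCN2CCN(c3ccccc3OC)CC2)C(=O)Nc2ccccc21`: 5.38 nM
- compound 3 `CCC1(CCCCN2CCN(c3ccc(F)cc3)CC2)C(=O)Nc2ccc(F)cc21`: 1.5 nM

Compound 2 stands at the highest number of the three; compound 3 and compound 1 both sit lower by gaps beyond the usual scatter, and those two lie within scatter of each other. Among the measured compounds shown here, no single-change pair among the measured compounds exists, so no measured step is available.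

Compound 4 `CCC1(CCCCN2CCN(c3ccc(Cl)c(Cl)c3)CC2)C(=O)Nc2ccccc21` is the analogue of compound 2 with 3,4-dichlorophenyl in place of 2-methoxyphenyl on an amine nitrogen in a ring. The expected direction is towards a lower number, as the other aryl groups in the set give lower numbers than compound 2 gives with 5.38 nM, and a step of modest size is expected for a 2.2-fold lower number from compound 2 to compound 4 (0.33 log units; beyond the scatter). Compound 4 is estimated at 2.5 nM, within 0.8 nM to 8 nM.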

Compound 4, inhibition constant: 0.63 nM
Compound 4: the middle estimate sits 4.0-fold (0.60 log units) above what was measured, and the stated range ends above it.
By their numbers in this assay, from the lowest: compound 4; then compounds 1 and 3 (each within the scatter of the next); then compound 2.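

In this assay, among the compounds shown here, 3,4-dichlorophenyl in place of 2-methoxyphenyl on the amine nitrogen in the ring gives an 8.5-fold lower number from compound 2 to compound 4 (0.93 log units; beyond the scatter), the first reading of this position on its own. The earlier compounds shown here differed in more than one place, so the share of the aryl group could not be isolated. Nothing measured here accounts for the step.

Still open, from the compounds shown here alone, is whether the step follows from losing the methoxy group or from gaining the chlorines. An unsubstituted phenyl or a monochlorophenyl on the same core would separate the two.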